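Notes on the ether chain: compound 3 to compound 4

The source may hold more compounds than are shown below. What is called first, only, known or untested is meant among the compounds shown, and "the series" means these compounds.

Measured so far in a functional assay on HEK293 cells for agonist activity at Free fatty acid receptor 1 (Homo sapiens), read by calcium flux; on this read-out lower numbers stand for an effect already at smaller amounts and higher numbers for an effect only at larger amounts of compound:
compound 1 `CCCCCOc1ccc(C(CC(=O)O)c2ccccc2)cc1` gives 2.97 uM
compound 2 `O=C(O)CC(c1ccccc1)c1ccc(OCCCC(F)(F)F)cc1` gives 3.16 uM
compound 3 `C=C(C)CCOc1ccc(C(CC(=O)O)c2ccccc2)cc1` gives 2.71 uM

Compound 3 holds the lowest of the three numbers, but a 1.1-fold lower number from compound 1 to compound 3 (0.04 log units; within the scatter) and a 1.2-fold lower number from compound 2 to compound 3 (0.07 log units; within the scatter), so nothing separates the three in this assay. Compound 4 `CCC(C)COc1ccc(C(CC(=O)O)c2ccccc2)cc1` is the next step: sec-butyl in place of 2-methylprop-2-en-1-yl on a saturated chain carbon bound to an oxygen on an aromatic ring. Among the compounds with values here, the steps that bear on it, a 1.1-fold higher number from compound 1 to compound 2 (0.03 log units; within the scatter) and a 1.1-fold lower number from compound 1 to compound 3 (0.04 log units; within the scatter), exchange chain ends further out from the oxygen, both within the scatter; no measured step touches the carbon bound to the oxygen itself. On this ground no step beyond the scatter is expected in this assay, in either direction. Compound 4 is estimated at 2.9 uM, range 1.4 uM to 6 uM, meaning an expected 1.1-fold higher number from compound 3 to compound 4 (0.03 log units; within the scatter).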

Compound 4, concentration for half-maximal effect: 0.3 uM
Compound 4: middle estimate off by 9.7-fold (0.99 log units), on the high side; measured number below the stated range.
By their numbers in this assay, from the lowest: compound 4; then compounds 3, 1 and 2 (each within the scatter of the next).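

In this assay, within the data shown here, this position, on a saturated chain carbon bound to an oxygen on an aromatic ring, gives the first steps beyond the scatter: a 9.0-fold lower number from compound 3 to compound 4 (0.96 log units; beyond the scatter), a 9.9-fold lower number from compound 1 to compound 4 (1.00 log units; beyond the scatter) and an 11-fold lower number from compound 2 to compound 4 (1.02 log units; beyond the scatter). Butyl, 3,3,3-trifluoropropyl and 2-methylprop-2-en-1-yl stay within the scatter of one another, so among these groups sec-butyl alone stands apart. No available data bear on why sec-butyl separates from the other three.

Open, on these data alone, is whether the lower number holds with a longer branched chain or a cyclopentyl group in place of sec-butyl.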